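The source may hold more compounds than are shown below. What is called first, only, known or untested is meant among the compounds shown, and "the series" means these compounds.

Within the series built on the core of compound 1 `Cc1c(C(=O)N/N=C\c2ccccc2C(F)(F)F)oc2cccc(O)c12`, the aryl group on the carbon with a double bond to nitrogen is varied. In a functional assay on PC-3 cells (Homo sapiens) for inhibition (a higher number here means a weaker inhibitor, a lower number a stronger inhibitor), compound 1 gives 26200 nM, compound 2 `Cc1c(C(=O)N/N=C\c2c(O)cccc2F)oc2cccc(O)c12` gives 8050 nM, and compound 3 `Cc1c(C(=O)N/N=C\c2cccc(O)c2O)oc2cccc(O)c12` gives 12200 nM. Compound 3 thus holds the second highest of the three numbers, with compound 2 nearest and compound 1 furthest. Compound 4 `Cc1c(C(=O)N/N=C\c2ccco2)oc2cccc(O)c12` differs by furan-2-yl in place of 2,3-dihydroxyphenyl on a carbon with a double bond to nitrogen. Among the compounds with values here, the one measured single-point step, a 1.5-fold higher number from compound 2 to compound 3 (0.18 log units; within the scatter), exchanges one substituent on the ring and does not speak to removing both hydrogen-bond donors together with a ring member. Compound 1, whose ring carries no hydrogen-bond donor, shows the highest number, which points mildly toward a higher number for compound 4. Compound 4 is expected in this assay at 22000 nM, within 7000 nM to 70000 nM, an estimated step of a 1.8-fold higher number from compound 3 to compound 4 (0.26 log units; within the scatter).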

Compound 4, half-maximal inhibitory concentration: >= 40000 nM
Compound 4 was reported as a limit; the forecaster's own chance of this, stated with the estimate: 10%; middle value at least 1.8-fold (0.25 log units) from the limit.
By their numbers in this assay, from the lowest: compounds 2 and 3 (each within the scatter of the next); then compound 1. At a limit, above all of these: compound 4.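

Within the data shown here, the furan-2-yl ring on the carbon with a double bond to nitrogen gives the first change at this position that clearly exceeds the scatter in this assay: an at least 3.2-fold higher number from compound 3 to compound 4 (0.51 log units; beyond the scatter), and an at least 4.9-fold higher number from compound 2 to compound 4 (0.69 log units; beyond the scatter). The value for compound 4 is a limit of the assay: the limit of >= 40000 nM in this assay, at which 1 of the 4 values shown sits. Loss of hydrogen-bond donors from the ring is not a sufficient reading, since compound 1 has none there and gives 26200 nM.

The limit leaves the full size of both steps open. Also open, from the compounds shown here alone, is whether a phenyl ring carrying an amine or a carboxylic acid would keep a measurable value.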